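The compounds below may be only part of what the source reports. "The series", "measured", "known", "first", "only" and "open" are said of these compounds alone.

Compound 1 `C/N=C(\S)CCn1nc(-c2ccccc2)ccc1=O` gives 68.2% in a functional assay on the whole organism (stomach) for inhibition, with Rattus norvegicus as the target, at a dose of 100 mg/kg by the intraduodenal route; a lower number here means less inhibition, a higher number more inhibition at the dose given (going by the name of the read-out).
Compound 2 `CC/N=C(\S)CCn1nc(-c2ccccc2)ccc1=O` gives 50.3% in this assay.
Compound 3 `N=C(S)CCCCCn1nc(-c2ccccc2)ccc1=O` gives 91.4% in this assay.

Compound 3 stands highest of the three measured numbers: a number 23.2 percentage points higher from compound 1 to compound 3 (beyond the scatter) and a number 41.1 percentage points higher from compound 2 to compound 3 (beyond the scatter). Compound 4 `CCOC(=O)CCn1nc(-c2ccccc2)ccc1=O` differs from compound 3 in one place: a group of 5 heavy atoms (3 carbon, 2 oxygen; no ring) in place of a group of 6 heavy atoms (4 carbon, 1 nitrogen, 1 sulfur; no ring), on a saturated chain carbon, two bonds along the chain from an aromatic nitrogen. Within the data shown here, no measured step covers this exchange, since all three measured compounds keep a chain with one nitrogen and one sulfur. The steps only show that changes to that chain shift the read-out by modest to large amounts, as in a number 17.9 percentage points lower from compound 1 to compound 2 (beyond the scatter). The expectation for compound 4 is therefore uncertain, with a drop more likely than a rise. Compound 4 is estimated at 50%, within 15% to 85%, an expected step of a number 41.4 percentage points lower from compound 3 to compound 4 (beyond the scatter).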

Compound 4, a percentage reported as inhibition, in the whole organism at one dose (the size of the read-out at that dose, not a potency): 6.3%
Compound 4: the middle estimate sits 43.7 percentage points above what was measured; measured number outside the range, below it.
By their numbers in this assay, from the lowest: compound 4; then compound 2; then compound 1; then compound 3.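

In this assay the drop appears whichever group is replaced: a number 85.1 percentage points lower from compound 3 to compound 4 (beyond the scatter) and a number 44 percentage points lower from compound 2 to compound 4 (beyond the scatter) and also a number 61.9 percentage points lower from compound 1 to compound 4 (beyond the scatter) when ethoxycarbonyl enters. The earlier compounds shown here all kept nitrogen and sulfur in this chain, so only now is it seen that inhibition can almost vanish with a group lacking both. Nothing available explains this loss. The compounds shown leave open how a carboxylic acid or an amide would read at this place, and whether a longer chain carrying ethoxycarbonyl would stay as low.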